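The source may report more compounds than this note shows. Statements on the series, on what has been measured and on what is new or still open speak of the compounds shown alone.

Measured compounds:
compound 1, `Cc1cc(Nc2cc(-c3ccccc3)[nH]n2)n2nc(SCc3c(Cl)cccc3Cl)nc2n1`: 39600 nM
compound 2, `Cc1cc(Nc2cc(-c3ccc(Cl)cc3)[nH]n2)n2nc(SCc3ccc(Br)cc3)nc2n1`: 28200 nM
compound 3, `Cc1cc(Nc2ccn(Cc3ccc(C(F)(F)F)cc3)n2)n2nc(SCc3ccc(Br)cc3)nc2n1`: 30200 nM

In an ADME assay on GES1 cells (Homo sapiens) for inhibition, read by MTT assay, with a stated time of 72 h (a lower number here means a stronger inhibitor, a higher number a weaker inhibitor), compound 1 gives 39600 nM. Compound 2 gives 28200 nM and compound 3 gives 30200 nM; all three numbers lie within the usual scatter of one another, so none of the three can be set apart from the others on these data.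

Compound 4, `C#CCSc1nc2nc(C)cc(Nc3cc(-c4ccccc4)[nH]n3)n2n1`, has not yet been measured. It differs from compound 1 in one place: ethynyl in place of 2,6-dichlorophenyl on a saturated chain carbon bound to a sulfur. Going by the values given here, no pair of measured compounds differs in a single place, so no measured step guides this change. With all three measured numbers so close, the step from compound 1 to compound 4 is expected to stay within the scatter, a 1.1-fold higher number from compound 1 to compound 4 (0.06 log units; within the scatter). Compound 4 is therefore estimated at 45000 nM in this assay, between 20000 nM and 100000 nM.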

Compound 4, half-maximal inhibitory concentration: 45700 nM
Estimate against measurement, compound 4: 1.0-fold (0.01 log units) below; the measured number falls inside the stated range.
By their numbers in this assay, from the lowest: compounds 2, 3, 1 and 4 (each within the scatter of the next).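

Going by these compounds alone, this is the first single-place comparison in the set: in this assay, ethynyl in place of 2,6-dichlorophenyl on a saturated chain carbon bound to a sulfur gives a 1.2-fold higher number from compound 1 to compound 4 (0.06 log units; within the scatter). The six-membered aromatic ring and both chlorines can therefore leave this place without a step beyond the scatter. Nothing measured here offers a reason for this. Going by these compounds, whether an amine, a carboxylic acid or a longer chain at this place would stay within the scatter remains open, as does whether any group here can move the number beyond it.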